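This account rests on a few compounds, and the source may have more. Where it says the series, first, only, none or still open, it means among the compounds named here.

In a functional assay on NCI-H522 cells (Homo sapiens) for inhibition, read by sulforhodamine B assay, with a stated time of 48 h (on this read-out higher numbers stand for weaker inhibition of growth and lower numbers for stronger inhibition of growth), compound 2 `COc1ccc(C(=O)/C=C/c2cc(-c3cc(OC)c(OC)c(OC)c3)n[nH]2)cc1` gives 1470 nM, the larger of the two numbers recorded, though its gap to compound 1 `COc1cc(-c2cc(/C=C/C(=O)c3ccc(Cl)c(Cl)c3)[nH]n2)cc(OC)c1OC`, which gives 1330 nM, is within the scatter. Compound 3 `COc1cc(-c2cc(/C=C/C(=O)c3ccc(F)c(F)c3)[nH]n2)cc(OC)c1OC` differs from compound 2 by 3,4-difluorophenyl in place of 4-methoxyphenyl on a carbonyl carbon. Among the measured compounds shown here, the only measured change at this position, a 1.1-fold higher number from compound 1 to compound 2 (0.04 log units; within the scatter), stayed within the scatter, so in this assay no step beyond the scatter is expected from this exchange either. Compound 3 is therefore estimated at 1400 nM, within a range of 600 nM to 3500 nM. That estimate corresponds to an expected step of a 1.1-fold lower number from compound 2 to compound 3 (0.02 log units; within the scatter).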

Compound 3, concentration for 50% growth inhibition: 1570 nM
Compound 3: middle estimate off by 1.1-fold (0.05 log units), on the low side, and the stated range covers the measured number.
By their numbers in this assay, from the lowest: compounds 1, 2 and 3 (each within the scatter of the next).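

In this assay the exchange of 4-methoxyphenyl for 3,4-difluorophenyl gives a 1.1-fold higher number from compound 2 to compound 3 (0.03 log units; within the scatter) and the exchange of 3,4-dichlorophenyl for 3,4-difluorophenyl gives a 1.2-fold higher number from compound 1 to compound 3 (0.07 log units; within the scatter) so all three groups on the carbonyl carbon sit within the scatter of one another. The hydrogen-bond acceptor counted in 4-methoxyphenyl can thus leave this position with no step beyond the scatter. Nothing available explains this level result. From the compounds shown here alone, what remains open is whether this level result holds for a group other than a substituted phenyl, such as an amine or a longer chain, at this position.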